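Swapping a halogen on the pendant aryl ring

The source may report more compounds than this note shows. Statements on the series, on what has been measured and on what is new or still open speak of the compounds shown alone.

Two sulfone-bearing analogues share one core. Compound 1 `O=S(=O)(c1ccc(F)cc1)c1cnc2cc(F)ccc2c1-c1ccc(Cl)cc1` gives 38.6 nM in an assay (strain Sprague-Dawley) for displacement of a labelled ligand from metabotropic glutamate receptor 5 (Rattus norvegicus), with a stated time of 60 min; a higher number here means a weaker inhibitor, a lower number a stronger inhibitor. Compound 2 `O=S(=O)(c1ccc(F)c(Cl)c1)c1cnc2cc(F)ccc2c1-c1ccc(F)cc1` gives 5.2 nM in this assay, the lower of the two numbers, with compound 1 standing higher by a gap beyond the usual scatter. Compound 3 `O=S(=O)(c1ccc(F)c(Cl)c1)c1cnc2cc(F)ccc2c1-c1ccc(Cl)cc1` differs from compound 2 by chloro in place of fluoro on an aromatic carbon, on an aromatic carbon para to a large group. For the measured compounds named here, no measured pair isolates this change, so a small step in this assay, in either direction or none beyond the scatter, is expected. Compound 3 is estimated at 7 nM, with a range of 2.5 nM to 20 nM, a step of a 1.3-fold higher number from compound 2 to compound 3 (0.13 log units; within the scatter) that is expected to stay near the scatter.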

Compound 3, inhibition constant: 8.3 nM
Compound 3: the middle estimate sits 1.2-fold (0.07 log units) below what was measured; the measured number falls inside the stated range.
By their numbers in this assay, from the lowest: compounds 2 and 3 (each within the scatter of the next); then compound 1.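

In this assay the swap from 4-fluorophenyl to 4-chlorophenyl gives a 1.6-fold higher number from compound 2 to compound 3 (0.20 log units; within the scatter) and so stays within the scatter. Chloro in place of hydrogen on an aromatic carbon gives a 4.7-fold lower number from compound 1 to compound 3 (0.67 log units; beyond the scatter) and lies beyond it, so among these compounds this is the change that separates the numbers, not the halogen on the pendant ring. No evidence shown accounts for either step. Still open, on these data alone, is how a methoxy group or an amine would fare in place of that pendant halogen.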